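This account rests on a few compounds, and the source may have more. Where it says the series, first, only, none or still open, it means among the compounds named here.

Compound 1 `CS(=O)(=O)c1ccc(-c2nc3ccccn3c2Sc2ccccc2)cc1`: 70600 nM
Compound 2 `COc1ccc(-c2nc3ccccn3c2Sc2ccccc2)cc1`: > 100000 nM

Both compounds were tested in a functional assay on HeLa cells (Homo sapiens) for inhibition, read by MTT assay, with a stated time of 48 h; a lower number here means a stronger inhibitor, a higher number a weaker inhibitor. For compound 2, the entry > 100000 nM is a limit of the assay and not a number. The evidence on this step therefore amounts to the limit of > 100000 nM in this assay, at which 1 of the 2 values shown sits. Going by the values given here, compound 1 gives 70600 nM, so the only true number in hand is a weak one.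

Compound 3 `c1ccc(Sc2c(-c3ccsc3)nc3ccccn23)cc1` keeps the shared core and the phenylsulfanyl group of compound 2, but has thiophen-3-yl in place of 4-methoxyphenyl on an aromatic carbon. Among the compounds with values here, only one measured step comes near this change, and it alters a group on the ring that compound 3 gives up, without replacing the ring itself: an at least 1.4-fold higher number from compound 1 to compound 2 (0.15 log units; that floor lies within the scatter). Within the data shown here, that step gives no clear size, and no measured step replaces the ring, so no firm direction can be drawn. Compound 3 is therefore expected to stay weak, near the limit, and it may itself return only a limit. The estimated at least 1.1-fold lower number from compound 2 to compound 3 (0.04 log units; that floor lies within the scatter) is expected to lie within the scatter. Compound 3 is expected at about 90000 nM, with an estimated range from 35000 nM to 200000 nM.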

Compound 3, half-maximal inhibitory concentration: 76000 nM
The estimate for compound 3 lay 1.2-fold (0.07 log units) above the measured number, and the stated range covers the measured number.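

In this assay, placing thiophen-3-yl instead of 4-methoxyphenyl on this aromatic carbon gives an at least 1.3-fold lower number from compound 2 to compound 3 (0.11 log units; that floor lies within the scatter), so exchanging the whole ring, and not only a group on it, still shows no clear direction. Compound 2 stands at a limit of the assay and not a number, and this step rests on that limit: the limit of > 100000 nM in this assay, at which 1 of the 3 values shown sits.

What is new is that this position accepts a five-membered aromatic ring containing sulfur, with fewer heavy atoms than 4-methoxyphenyl, and still yields a true number: compound 1 gives 70600 nM and compound 3 gives 76000 nM, both weak values.

The compounds shown leave open whether any group at this position can give a strong inhibitor of this kind, for example a phenyl ring carrying an amine or a carboxylic acid, or a longer chain such as butyl in place of the ring. They also leave open whether changes elsewhere, such as a chlorine atom or a hydroxyl group on the phenylsulfanyl ring, would matter more than the exchange at this position.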